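Piperazin-1-yl in place of cyclohexyl: working notes

The source may report more compounds than this note shows. Statements on the series, on what has been measured and on what is new or still open speak of the compounds shown alone.

Among the measured compounds shown here, in a functional assay on C6 cells (Rattus norvegicus) for inhibition, read by sulforhodamine B assay, with a stated time of 72 h (a higher number here means that more compound is needed for the effect, a lower number that less compound is needed), compound 2 `O=C(/C=C/c1ccc([N+](=O)[O-])o1)c1ccc(C2CCCCC2)cc1` gives 5100 nM, the lowest of the two numbers so far. Compound 1 `O=C(/C=C/c1ccc([N+](=O)[O-])o1)c1ccc(N2CCCC2)cc1` gives 16400 nM on the same shared core.

The next structure, compound 3 `O=C(/C=C/c1ccc([N+](=O)[O-])o1)c1ccc(N2CCNCC2)cc1`, carries piperazin-1-yl in place of cyclohexyl on an aromatic carbon.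

For the measured compounds named here, one measured step bears on this change: a 3.2-fold lower number from compound 1 to compound 2 (0.51 log units; beyond the scatter), a modest move beyond the scatter, with cyclohexyl in place of pyrrolidin-1-yl. Compound 1 and compound 3 both hold nitrogen in the ring at this place, whereas compound 2 holds a ring of carbon only. Going by the values given here, no measured compound carries piperazin-1-yl, and a single step cannot show how far the comparison transfers.

A step of similar or somewhat smaller size, toward a higher number, is therefore expected in this assay. The estimated move is a 2.2-fold higher number from compound 2 to compound 3 (0.33 log units; beyond the scatter). For compound 3, the expected value is 11000 nM, with an estimated range of 3500 nM to 30000 nM.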

Compound 3, half-maximal effective concentration: 1500 nM
For compound 3 the middle estimate is 7.3-fold (0.87 log units) above the measured one; the whole stated range lies above it.
By their numbers in this assay, from the lowest: compound 3; then compound 2; then compound 1.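

In this assay, among the compounds shown here, piperazin-1-yl on this aromatic carbon gives a 3.4-fold lower number from compound 2 to compound 3 (0.53 log units; beyond the scatter), so a ring holding nitrogen at this place does not always go with a higher number than the cyclohexyl ring of carbon only, as the single earlier step had suggested. The two nitrogen-bearing rings also lie far apart, with an 11-fold lower number from compound 1 to compound 3 (1.04 log units; beyond the scatter) as the largest step in the series, and the carbon-only compound 2 falls between them, so the presence of ring nitrogen alone does not set the order at this place. No measurement is available that accounts for this order of the three groups.

The compounds shown leave open whether the lower number of compound 3 follows the second ring nitrogen, the hydrogen-bond donor counted on piperazin-1-yl, or the two together, and whether the order holds on any core other than the shared one. Piperidin-1-yl, morpholin-4-yl and 4-methylpiperazin-1-yl at the same place would bear directly on this question, as would an open-chain amine.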